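This account rests on a few compounds, and the source may have more. Where it says the series, first, only, none or still open, it means among the compounds named here.

In an ADME assay on PANC-1 cells (Homo sapiens) for cytotoxicity, read by MTT assay (a lower number here means that less compound is tolerated, a higher number that more compound is tolerated), compound 2 `Cc1nc(-c2cccnc2)sc1-c1nnc(-c2ccccc2)o1` reaches only a limit of the assay, reported as > 100 ug/mL. Compound 1 `Cc1nc(-c2cccnc2)sc1-c1nnc(-c2ccccc2Cl)o1` is likewise reported in this assay only as a limit, > 100 ug/mL. Compound 3 `Cc1ccc(-c2nnc(-c3sc(-c4cccnc4)nc3C)o2)cc1` is also given in this assay as a limit, > 100 ug/mL. Because of the limit of > 100 ug/mL in this assay, at which 3 of the 3 values shown sit, none of the steps between these three compounds can be read: a step that the two limits leave unreadable from compound 1 to compound 2, a step that the two limits leave unreadable from compound 1 to compound 3 and a step that the two limits leave unreadable from compound 2 to compound 3 all stay without a readable size. Compound 4 `Cc1nc(-c2cccnc2)sc1-c1nnc(-c2cccnc2)o1` has not yet been measured; it differs from compound 2 by pyridin-3-yl in place of phenyl on an aromatic carbon. The three measured steps, each hidden behind the limit, offer no size and no direction for this change, so no step beyond the usual scatter can be predicted from them. The step expected here, a step that the limit leaves unreadable from compound 2 to compound 4, is therefore small, and the most likely outcome is once more a value at a limit of the assay. For compound 4 the estimate in this assay is 150 ug/mL, with a range from 60 ug/mL to 400 ug/mL.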

Compound 4, half-maximal cytotoxic concentration: > 100 ug/mL
Compound 4: no number, only a limit; the forecaster's own chance of this, stated with the estimate: 85%; the middle value is on the limit's open side.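

Compound 4 is reported only as a limit, as are compound 1, compound 2 and compound 3, so no step from compound 4 to any of them can be read: the limit of > 100 ug/mL in this assay, at which 4 of the 4 values shown sit.

From the compounds shown here alone, how far each compound lies past that limit in this assay stays open, as does whether pyridin-3-yl in place of phenyl changes the result at all.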